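From acetyl to dimethylcarbamoyl on compound 2

The source may hold more compounds than are shown below. What is called first, only, known or untested is meant among the compounds shown, and "the series" means these compounds.

In a functional assay on the whole organism for agonist activity, with Mus musculus as the target (a lower number here means that less compound is needed, a higher number that more compound is needed for the effect), compound 1 `CC(=O)N(C)CC#CCn1ccnc1` gives 1.4 mg/kg. Compound 2 `CC(=O)N(C)CC#CCn1cncc1C`, with methyl in place of hydrogen on an aromatic carbon, gives > 100 mg/kg in this assay, and this is a limit of the assay, not a number. Among the compounds with values here, the only measured step is large and beyond the scatter: an at least 71-fold higher number from compound 1 to compound 2 (1.85 log units; beyond the scatter).

Compound 3 `Cc1cncn1CC#CCN(C)C(=O)N(C)C` keeps that methyl and differs from compound 2 in one place: dimethylamino in place of methyl on a carbonyl carbon. This is dimethylamino in place of methyl on a carbonyl carbon, or acetyl to dimethylcarbamoyl. Within the data shown here, no measured step covers a change at this carbonyl carbon, so the size of its effect cannot be read directly from the data. Among the measured compounds shown here, the one measured step bears on it only indirectly, through the methyl that compound 3 retains. No return towards compound 1 is expected for compound 3 because of an at least 71-fold higher number from compound 1 to compound 2 (1.85 log units; beyond the scatter), and a report of only a limit is the likelier outcome. The expected change is no shift beyond the scatter, with an estimated a number no higher from compound 2 to compound 3 (the limit leaves the size open). For compound 3 the estimated value in this assay is 100 mg/kg, with an expected range from 30 mg/kg to 300 mg/kg.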

Compound 3, dose for half-maximal effect: > 100 mg/kg
Compound 3 was reported as a limit (the forecaster's own chance of this, stated with the estimate: 75%); the middle value sits exactly at the limit.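

In this assay, no step from compound 2 to compound 3 can be read, because each of the two is reported only as a limit and not as a number: the limit of > 100 mg/kg in this assay, at which 2 of the 3 values shown sit.

The compounds shown leave open what dimethylamino in place of methyl on a carbonyl carbon does to the dose needed, with or without the methyl that compound 2 and compound 3 share.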